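Chloro to trifluoromethyl in a series at its limit

The source may hold more compounds than are shown below. What is called first, only, known or untested is meant among the compounds shown, and "the series" means these compounds.

Compound 1 `C=C[C@@](C)(/C=C/c1ccc(Nc2ccccc2)cc1)CCC=C(C)C`: > 52000 nM (a limit)
Compound 2 `C=C[C@@](C)(/C=C/c1ccc(Nc2ccc(F)cc2)cc1)CCC=C(C)C`: > 52000 nM (a limit)
Compound 3 `C=C[C@@](C)(/C=C/c1ccc(Nc2ccc(Cl)cc2)cc1)CCC=C(C)C`: > 52000 nM (a limit)

In a functional assay on HepG2 cells (Homo sapiens) for cytotoxicity, with a stated time of 72 h (a lower number here means that less compound is needed, a higher number that more compound is needed for the effect), compound 3 gives only a limit, > 52000 nM, and not an exact number. It shares this position with the other two measured compounds, as the series shows (the limit of > 52000 nM in this assay, at which 3 of the 3 values shown sit).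

The next compound is compound 4 `C=C[C@@](C)(/C=C/c1ccc(Nc2ccc(C(F)(F)F)cc2)cc1)CCC=C(C)C`, which differs from compound 3 in one group: trifluoromethyl in place of chloro on an aromatic carbon. The change is trifluoromethyl in place of chloro on an aromatic carbon, para to a large group.

Among the measured compounds shown here, three measured steps bear on this change, since each also swaps one group on an aromatic carbon: a step that the two limits leave unreadable from compound 1 to compound 2, a step that the two limits leave unreadable from compound 1 to compound 3 and a step that the two limits leave unreadable from compound 2 to compound 3. None of them has a size that can be read, so they offer no direction and no measure of how far such a swap moves the result in this assay. The expectation is therefore no step beyond the usual scatter, and another limit is the most likely report.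

The estimated change is a number no higher from compound 3 to compound 4 (the limit leaves the size open).

For compound 4 the expected value is 52000 nM, with an estimated range from 30000 nM to 80000 nM.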

Compound 4, half-maximal effective concentration: > 52000 nM
Compound 4: no number, only a limit; the forecaster's own chance of this, stated with the estimate: 85%; the middle value lies on the limit itself.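

In this assay compound 4 gives > 52000 nM, which is a limit and not a number. Its steps from compound 1, compound 2 and compound 3 therefore cannot be read, and the series stays where it was: the limit of > 52000 nM in this assay, at which 4 of the 4 values shown sit.

The compounds shown leave open how much of any of them is needed for the effect, and whether swapping this group can change that amount at all.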